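The source may hold more compounds than are shown below. What is called first, only, known or untested is meant among the compounds shown, and "the series" means these compounds.

The study at hand covers three measured compounds and one that has yet to be tested. Compound 1 `CC(COC(=O)N1CCc2cc(S(C)(=O)=O)ccc21)C1CCN(C(=O)OC(C)(C)C)CC1` gives 8.4 nM in a functional assay on CHO cells for agonist activity at Glucose-dependent insulinotropic receptor (Homo sapiens), read by a luciferase reporter and cAMP accumulation, with a stated time of 2 h; on this read-out higher numbers stand for an effect only at larger amounts of compound and lower numbers for an effect already at smaller amounts. Compound 2 `COc1cc2c(cc1S(C)(=O)=O)CCN2C(=O)OCCC1CCN(C(=O)OC(C)(C)C)CC1` gives 4800 nM in this assay. Compound 3 `CC(C)(C)OC(=O)N1CCC(CCOC(=O)N2CCc3cc(S(C)(=O)=O)cc(F)c32)CC1` gives 25 nM in this assay. Among these three numbers, compound 3 stands second highest: its nearest neighbour is compound 1, whose lower number lies beyond the usual scatter, and its furthest is compound 2, whose far higher number also lies well beyond the scatter.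

Compound 4 `Cc1cc(S(C)(=O)=O)cc2c1N(C(=O)OCCC1CCN(C(=O)OC(C)(C)C)CC1)CC2` differs from compound 3 by a single exchange, (methyl in place of fluoro on an aromatic carbon), that is, methyl in place of fluoro on an aromatic carbon. Among the measured compounds shown here, no measured pair in this set shows this exchange, so its effect cannot be read off directly. The author expects only a small step in this assay from compound 3 to compound 4, possibly none beyond the scatter, with the direction uncertain and a slight lean toward a higher number; this expectation is written as a 1.4-fold higher number from compound 3 to compound 4 (0.15 log units; within the scatter). On that basis compound 4 is estimated at 35 nM in this assay, with a range from 9 nM to 140 nM.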

Compound 4, half-maximal effective concentration in the Glucose-dependent insulinotropic receptor assay: 44 nM
Estimate against measurement, compound 4: 1.3-fold (0.10 log units) below; the measured number falls inside the stated range.
By their numbers in the Glucose-dependent insulinotropic receptor assay, from the lowest: compound 1; then compounds 3 and 4 (each within the scatter of the next); then compound 2.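

In the Glucose-dependent insulinotropic receptor assay, placing methyl instead of fluoro on the aromatic carbon meta to a methylsulfonyl group gives a 1.8-fold higher number from compound 3 to compound 4 (0.25 log units; within the scatter), so this one pair shows that the position can carry either group with no difference this assay can resolve. In a physicochemical assay for solubility, read by HPLC, at pH 6.8 (a higher number here means a more soluble compound, a lower number a less soluble compound), the same exchange gives a 1.0-fold higher number from compound 3 to compound 4 (0.02 log units; within the scatter), with compound 3 at 42 ug/mL and compound 4 at 44 ug/mL, so this read-out does not separate the two compounds either. Among the compounds shown here, the earlier compounds offered no pair differing in one place, which makes this the first single change that can be read in the set, though nothing available explains why the two groups give such similar numbers.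

What the compounds shown leave open is how far this tolerance extends, as fluoro and methyl are the only two groups seen at this carbon, and a nitrile, a trifluoromethyl group or an amine there could give quite different numbers in the Glucose-dependent insulinotropic receptor assay. From the compounds shown here alone, it also remains open whether the exchange would give an equally small step on a different version of the core, since it appears here in a single pair.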